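A methylsulfonyl exchange on compound 2

The source may report more compounds than this note shows. Statements on the series, on what has been measured and on what is new or still open speak of the compounds shown alone.

- Compound 1 `CSCC(=O)N1CCSC1COc1ccccc1O`: 28 mg/kg
- Compound 2 `COc1ccccc1OCC1N(C(=O)C[S+](C)[O-])CC[S+]1[O-]`: 25 mg/kg

Only these two compounds have been measured in a functional assay on the whole organism (trachea) for inhibition, with Cavia porcellus as the target; a higher number here means that more compound is needed for the effect, a lower number that less compound is needed. Among the measured compounds shown here, compound 2 gives 25 mg/kg, and this number lies within the scatter of the one for compound 1, so the two cannot be ranked.

Compound 3 `COc1ccccc1OCC1N(C(=O)CS(C)(=O)=O)CC[S+]1[O-]` has not yet been measured. Its difference from compound 2 is a group of 4 heavy atoms (1 carbon, 2 oxygen, 1 sulfur; no ring) in place of a group of 3 heavy atoms (1 carbon, 1 oxygen, 1 sulfur; no ring), on a saturated chain carbon bound to a carbonyl carbon. A methylsulfonyl group thus enters on a saturated chain carbon bound to a carbonyl carbon, and the rest of the structure stays the same.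

For the measured compounds named here, no two measured compounds differ in one place only, so the data do not show directly what such a change does in this assay. Going by the values given here, the only guide is that the two measured values, although from different structures, sit within the scatter of each other. No step beyond the scatter is therefore expected, and neither direction is favoured. The expected step is no change at the digits printed from compound 2 to compound 3 (within the scatter). For compound 3 the estimate is 25 mg/kg, with an expected range of 10 mg/kg to 60 mg/kg.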

Compound 3, dose for half-maximal effect: 28 mg/kg
For compound 3 the middle estimate is 1.1-fold (0.05 log units) below the measured one; low and high end bracket the measured number.
By their numbers in this assay, from the lowest: compounds 2, 1 and 3 (each within the scatter of the next).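

In this assay, among the compounds shown here, the exchange of the group on a saturated chain carbon bound to a carbonyl carbon for methylsulfonyl gives a 1.1-fold higher number from compound 2 to compound 3 (0.05 log units; within the scatter) and is the first step between compounds that differ in one place. It shows directly what the two earlier values, taken from different structures, could only suggest: at this position, 4 heavy atoms and 2 hydrogen-bond acceptors can stand in place of 3 heavy atoms and 1 hydrogen-bond acceptor without a step that can be told from the scatter in this assay. No measurement on the compounds bears on why this is so, so the result remains an observation without an explanation.

What the compounds shown leave open is whether a group of another kind on this carbon, such as an amine, a carboxylic acid or a longer chain, would also stay within the scatter, or would give a step beyond it. They also leave open whether methylsulfonyl would behave in the same way on the core of compound 1, which differs from compound 3 in more than one place.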